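This account rests on a few compounds, and the source may have more. Where it says the series, first, only, none or still open, it means among the compounds named here.

Working notes on the series.

All three measured compounds share a core that differs only in its pendant groups. Compound 1 is `COc1cccc(Nc2ncnc3cc(OC)c(OCCCN4CCNCCNCCNCC4)cc23)c1`. In a functional assay on A549 cells (Homo sapiens) for antiproliferative activity, read by MTT assay, with a stated time of 72 h (on this read-out higher numbers stand for weaker inhibition and lower numbers for stronger inhibition), compound 1 gives a limit of the assay, > 50000 nM. Compound 2 is `COc1cc2ncnc(Nc3cccc(F)c3)c2cc1OCCCN1CCNCCNCCNCC1`. In this assay compound 2 likewise gives a limit, > 50000 nM. Compound 3 is `COc1cccc(Nc2ncnc3cc(OC)c(OCCCN4CCNCCNCC4)cc23)c1`. In this assay compound 3 also gives a limit, > 50000 nM.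

The two cores differ as a group of 9 heavy atoms (6 carbon, 3 nitrogen; one nine-membered non-aromatic ring with 3 hetero atoms) in place of a group of 12 heavy atoms (8 carbon, 4 nitrogen; one twelve-membered non-aromatic ring with 4 hetero atoms), on a saturated chain carbon, three bonds along the chain from an oxygen on an aromatic ring, and the step that the two limits leave unreadable from compound 1 to compound 3 cannot be sized from the two limits. From compound 1 to compound 2 the change is fluoro in place of methoxy on an aromatic carbon; the step that the two limits leave unreadable from compound 1 to compound 2 is equally unreadable, since both ends sit at the limit of > 50000 nM in this assay, at which 3 of the 3 values shown sit.

Compound 4, not yet measured, is `COc1cc2ncnc(Nc3cccc(F)c3)c2cc1OCCCN1CCNCCNCC1`. It differs from compound 3 by fluoro in place of methoxy on an aromatic carbon, the same change as that from compound 1 to compound 2, made at the same place. Going by the values given here, because every value shown sits at the limit of > 50000 nM in this assay, at which 3 of the 3 values shown sit, no size can be assigned to the earlier step, and nothing among the measured compounds points to activity appearing when the same change is made on the core of compound 3. The step from compound 3 to compound 4 in this assay is therefore expected to be a step that the limit leaves unreadable from compound 3 to compound 4, and compound 4 is most likely to return a limit rather than a number. Compound 4 is estimated at 80000 nM, expected to lie between 20000 nM and 400000 nM.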

Compound 4, half-maximal inhibitory concentration: > 50000 nM
Compound 4: no number, only a limit; the forecaster's own chance of this, stated with the estimate: 85%; the middle value is on the limit's open side.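

In this assay compound 4 gives the limit > 50000 nM and no number. No size can be read for the steps from compound 3 to compound 4 or from compound 2 to compound 4, because all of their ends are limits: the limit of > 50000 nM in this assay, at which 4 of the 4 values shown sit.

The compounds shown leave open whether fluoro in place of methoxy, or the smaller in place of the larger non-aromatic ring, changes antiproliferative potency at all.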